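The source may hold more compounds than are shown below. What is called first, only, known or untested is meant among the compounds shown, and "the series" means these compounds.

Measured compounds:
- Compound 1, `CS(=O)(=O)c1ccc(Cc2nnc3n2N=C(c2ccc(Cl)cc2Cl)CS3)cc1` — in a functional assay on RAW264.7 cells (Mus musculus) for cytotoxicity, read by MTT assay, with a stated time of 48 h, tested at 25 uM (a lower number here means a weaker effect, a higher number a stronger effect of the compound at the concentration tested), compound 1 gives 24.2%.
- Compound 2, `Cc1ccc(C2=Nn3c(Cc4ccc(S(C)(=O)=O)cc4)nnc3SC2)cc1` — in this assay compound 2 gives 1.26%.
- Compound 3, `CS(=O)(=O)c1ccc(Cc2nnc3n2N=C(c2cc(Cl)sc2Cl)CS3)cc1` — in this assay compound 3 is reported as "not active" (no number reported), without a number.

Compound 2 stands lowest of the two numbers available; its nearest neighbour is compound 1, and the step of a number 22.9 percentage points lower from compound 1 to compound 2 (beyond the scatter) is beyond the scatter though modest. Compound 3 adds no number to place it against.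

Compound 4, `CS(=O)(=O)c1ccc(Cc2nnc3n2N=C(c2ccc(-c4ccccc4)cc2)CS3)cc1`, is not yet measured. It differs from compound 2 by phenyl in place of methyl on an aromatic carbon. Among the measured compounds shown here, no measured pair changes this position, so nothing bears directly on the step. For the measured compounds named here, the only step measured, a number 22.9 percentage points lower from compound 1 to compound 2 (beyond the scatter), concerns the other aromatic ring and shows that a change there moved the read-out by a modest amount. Given that compound 2 gives 1.26% and compound 1 gives 24.2%, the series so far spans a narrow band of weak effects, and no change yet has produced a strong one. The expectation for compound 4 is therefore a step of a number 6.7 percentage points higher from compound 2 to compound 4 (within the scatter) of uncertain direction and probably within or only just beyond the scatter. Compound 4 is estimated at 8%, with a range from 0% to 30%.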

Compound 4, a percentage reported as activity, at one concentration (the size of the read-out at that concentration, not a potency): 60.2%
For compound 4 the middle estimate is 52.2 percentage points below the measured one; measured number above the stated range.
By their numbers in this assay, from the lowest: compound 2; then compound 1; then compound 4.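

In this assay, among the compounds shown here, the position on the aromatic ring that holds methyl in compound 2 turns out to be a sensitive one: phenyl in place of methyl gives a number 58.9 percentage points higher from compound 2 to compound 4 (beyond the scatter) and is a large step, whereas the only earlier step, a number 22.9 percentage points lower from compound 1 to compound 2 (beyond the scatter), was modest. With compound 4 at 60.2%, this series now has a member well clear of the low readings, so the read-out in this assay is not confined to weak effects, and the change that shows this is one added aromatic ring of carbon only. Nothing measured here accounts for the size of this rise.

From the compounds shown here alone, with only methyl and phenyl compared at this place, it stays open whether the ring itself or simply the larger carbon group carries the step. A butyl chain, a cyclohexyl ring or an amine at the same place would help to separate these readings.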